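The compounds below may be only part of what the source reports. "The series", "measured", "known", "first", "only" and "open" are said of these compounds alone.

Compound 2 `CC(CCNC(=O)c1c(Cl)cncc1Cl)N1CCC(C(Oc2cccc(C(=O)O)n2)c2ccc(C(F)(F)F)cc2)CC1` shows the higher of the two numbers measured in an ADME assay on PBMC cells (Homo sapiens) for cytotoxicity (on this read-out higher numbers stand for lower toxicity in this test and lower numbers for higher toxicity in this test), giving 28700 nM in that test. Compound 1 `Cc1cccc(OC(c2ccc(Br)cc2)C2CCN(C(C)CCNC(=O)c3c(Cl)cncc3Cl)CC2)n1`, with a different aryl ether and a bromophenyl group, gives 6500 nM in this assay, a gap beyond the scatter. Compound 3 `CC(CCNC(=O)c1c(Cl)cncc1Cl)N1CCC(C(Oc2cccc(C(F)(F)F)c2)c2ccc(C(F)(F)F)cc2)CC1` differs from compound 2 in one place: 3-(trifluoromethyl)phenyl in place of 6-carboxypyridin-2-yl on an oxygen on a saturated carbon. Because compound 1, which also lacks the 6-carboxypyridin-2-yl group, gives 6500 nM, a downward step a 4.8-fold lower number from compound 2 to compound 3 (0.68 log units; beyond the scatter) beyond the scatter is expected. Compound 3 is therefore estimated at 6000 nM, within a range from 2000 nM to 18000 nM.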

Compound 3, half-maximal cytotoxic concentration: 7000 nM
Compound 3: the middle estimate sits 1.2-fold (0.07 log units) below what was measured; the range from low to high includes it.
By their numbers in this assay, from the lowest: compounds 1 and 3 (each within the scatter of the next); then compound 2.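

On an oxygen on a saturated carbon, 3-(trifluoromethyl)phenyl in place of 6-carboxypyridin-2-yl gives a 4.1-fold lower number from compound 2 to compound 3 (0.61 log units; beyond the scatter) in this assay. With the rest of the compound unchanged, this one position is enough to move the number beyond the scatter, and the higher number goes with the 6-carboxypyridin-2-yl group.

The compounds shown leave open whether the carboxylic acid or the ring nitrogen carries this step, which a phenyl ring bearing a carboxylic acid or a pyridine ring bearing trifluoromethyl could separate. No measurement shown accounts for the step.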